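A few compounds are considered here, and "the series" means these few. Any claim that something is new, unique, unknown or untested is made for them only; others in the source may bear on it.

Three compounds have so far been tested in a functional assay on the whole organism for inhibition, with Rattus norvegicus as the target, at a dose of 25 mg/kg by the intraperitoneal route; a lower number here means less inhibition, a higher number more inhibition at the dose given (going by the name of the read-out):

compound 1 `Cc1ccc(Cn2cnc3c(N(C)C)ncnc32)cc1` gives 0%
compound 2 `CN(C)c1ncnc2c1ncn2Cc1ccc([N+](=O)[O-])cc1` gives 0%
compound 3 `CN(C)c1ncnc2c1ncn2Cc1ccc(O)cc1` gives 0%

All three share one core and differ only in the group carried on the outer six-membered carbon ring. Compound 3 stands level with compounds 1 and 2: the step of no change at the digits printed from compound 1 to compound 3 (within the scatter) and the step of no change at the digits printed from compound 2 to compound 3 (within the scatter) both show no movement, and the step of no change at the digits printed from compound 1 to compound 2 (within the scatter) is just as flat. In other words, replacing methyl by nitro or by hydroxy on that aromatic carbon did nothing that rises above the scatter of this assay.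

Compound 4 `CC(=O)Nc1ccc(Cn2cnc3c(N(C)C)ncnc32)cc1` continues along the same position. Compared with compound 3, the change is acetamido in place of hydroxy on an aromatic carbon. The group that enters is larger than the one that leaves, but it sits at the very place where three different groups have already given the same flat result, so the measured steps that bear on this one all point the same way: none of them moved the read-out.

The step of no change at the digits printed from compound 3 to compound 4 (within the scatter) is therefore expected to stay within the scatter, with no direction to it. For compound 4 the estimate is 0%, with a range from 0% to 12%.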

Compound 4, a percentage reported as inhibition, in the whole organism at one dose (the size of the read-out at that dose, not a potency): 0%
Compound 4: the middle estimate sits on the measured number at the digits printed; the measured number falls inside the stated range.
By their numbers in this assay, from the lowest: compounds 1, 2, 3 and 4 (each within the scatter of the next).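

In this assay, acetamido, with 4 heavy atoms where hydroxy has 1, gives no change at the digits printed from compound 3 to compound 4 (within the scatter) on this aromatic carbon. Set against the other two groups, it gives no change at the digits printed from compound 2 to compound 4 (within the scatter) and no change at the digits printed from compound 1 to compound 4 (within the scatter), so a fourth group, now one with a double bond outside the aromatic rings, joins the same flat result, and no group shown at this place separates from the others. No measurement at hand accounts for this flat result. 

With every compound shown at the same reading, the series cannot tell whether this place has no influence on the read-out or whether the shared core gives no inhibition at this dose whatever the group carried there. As far as these compounds go, it remains open whether an amine or a carboxylic acid on this aromatic carbon would give a reading that differs from these, and whether a change elsewhere on the shared core, such as a longer chain in place of a methyl on the dimethylamino group, would do so.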